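This account rests on a few compounds, and the source may have more. Where it says the series, first, only, none or still open, it means among the compounds named here.

Compound 1 `O=S(=O)(c1ccc(Oc2ccc(OC(F)(F)F)cc2)cc1)C1CCC2(CCNCC2)C1` carries a hydrogen on a saturated ring carbon of the shared core. In a functional assay on blood (Homo sapiens), with a stated time of 60 min, in the presence of a further agent that is not named here (a lower number here means that less compound is needed, a higher number that more compound is needed for the effect), compound 1 gives only a limit, > 15000 nM. Compound 2 `NC(=O)C1(S(=O)(=O)c2ccc(Oc3ccc(OC(F)(F)F)cc3)cc2)CCC2(CCNCC2)C1` bears a carbamoyl on that carbon instead, and in this assay compound 2 gives 3700 nM. That change brings an at least 4.0-fold lower number from compound 1 to compound 2 (0.60 log units; beyond the scatter). Among the compounds with values here, compound 2 therefore holds the only actual number among the two values shown; the other value sits at the limit of > 15000 nM in this assay, at which 1 of the 2 values shown sits.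

Compound 3 `CS(=O)(=O)NC(=O)C1(S(=O)(=O)c2ccc(Oc3ccc(OC(F)(F)F)cc3)cc2)CCC2(CCNCC2)C1` differs from compound 2 by methylsulfonyl in place of hydrogen on an amide-type nitrogen. Within the data shown here, the single measured step concerns a carbamoyl entering on a saturated ring carbon, whereas the new change sits on the amide-type nitrogen of that carbamoyl, so no measured step speaks to this place directly; compound 2 offers only a starting point. With nothing measured at the nitrogen itself, one expects a step in this assay no larger than the scatter, in either direction. The value of compound 3 in this assay is thus estimated at 3000 nM, within 1000 nM to 10000 nM. The expected step is a 1.2-fold lower number from compound 2 to compound 3 (0.09 log units; within the scatter).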

Compound 3, half-maximal effective concentration: > 15000 nM
Compound 3: a limit, no number (the forecaster's own chance of this, stated with the estimate: 15%); at least 5.0-fold (0.69 log units) between middle value and limit.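

The amide-type nitrogen of the carbamoyl proves to be a place that responds in this assay: methylsulfonyl in place of hydrogen there brings an at least 4.0-fold higher number from compound 2 to compound 3 (0.60 log units; beyond the scatter), so that the saturated ring carbon is no longer the only place with a measured effect. Within the data shown here, the lower number that came with the carbamoyl does not persist once this group stands on its nitrogen, and compound 2 remains the only one of the three compounds with an actual number: the limit of > 15000 nM in this assay, at which 2 of the 3 values shown sit. The step from compound 1 to compound 3 cannot be read, as both values are limits.

With methylsulfonyl as the only group shown on that nitrogen, it remains open whether the higher number belongs to this particular group or would also follow with a methyl or an acetyl in place of the amide hydrogen. Also open, going by these compounds, is how a carboxylic acid or a nitrile in place of the whole carbamoyl on the saturated ring carbon would compare with compound 2 in this assay.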